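A few compounds are considered here, and "the series" means these few. Any claim that something is new, unique, unknown or untested is made for them only; others in the source may bear on it.

Compound 3 `CC(=O)CSc1nc(Cc2c(F)cccc2F)cc(=O)[nH]1` carries an acetyl group on the saturated chain carbon bound to sulfur. In an ADME assay on MT4 cells (Homo sapiens) for cytotoxicity, read by MTT assay (a lower number here means that less compound is tolerated, a higher number that more compound is tolerated), compound 3 gives > 81000 nM, which is a limit of the assay and not a number. Compound 1 `O=c1cc(Cc2c(F)cccc2F)nc(SCc2ccccc2)[nH]1`, with phenyl in that place, gives > 73000 nM, also a limit. Compound 2 `O=c1cc(Cc2c(F)cccc2F)nc(SCCCc2ccccc2)[nH]1`, with phenethyl there, gives a true number, 32000 nM. Compound 3 thus stands at the well-tolerated end of the series, although a step that the two limits leave unreadable from compound 1 to compound 3.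

The next change leads to compound 4 `O=C(CSc1nc(Cc2c(F)cccc2F)cc(=O)[nH]1)c1ccccc1`: phenyl in place of methyl on a carbonyl carbon, or acetyl to benzoyl. Two measured steps on this chain bear on it: an at least 2.2-fold lower number from compound 1 to compound 2 (0.35 log units; beyond the scatter), and an at least 2.5-fold higher number from compound 2 to compound 3 (0.40 log units; beyond the scatter). Both are modest, and both show compound 2 with the lower number. Compound 1 also carries a phenyl yet reports only a limit, so an added ring need not lower the number. A modest step to a lower number in this assay is expected, and another limit is quite possible. The expected change is an at least 1.6-fold lower number from compound 3 to compound 4 (0.20 log units; that floor lies within the scatter). For compound 4 the estimated value is 50000 nM, within an expected range of 22000 nM to 100000 nM.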

Compound 4, half-maximal cytotoxic concentration: > 67000 nM
Compound 4: a limit, no number; the forecaster's own chance of this, stated with the estimate: 55%; at least 1.3-fold (0.12 log units) between middle value and limit.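

In this assay, benzoyl in place of phenethyl on the saturated chain carbon bound to sulfur gives an at least 2.0-fold higher number from compound 2 to compound 4 (0.32 log units; beyond the scatter). Phenyl in place of methyl on the carbonyl carbon adds a six-membered aromatic ring, yet compound 4 joins compound 1 and compound 3 in reporting a limit, so among these four only compound 2 has reached a true number. Compound 4 gives only a limit, so its steps from compound 3 and from compound 1 cannot be read: the limit of > 67000 nM in this assay, at which 1 of the 4 values shown sits.

Where the true values of compound 1, compound 3 and compound 4 lie stays open, and with it whether methyl or phenyl on the carbonyl carbon makes any difference. Also open, on these data alone, is how an amine or a longer chain on that carbonyl carbon would read in this assay.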